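Swapping allyloxy for allylamino in a cytotoxicity series

The source may hold more compounds than are shown below. What is called first, only, known or untested is meant among the compounds shown, and "the series" means these compounds.

Going by the values given here, in a functional assay on HFF cells (Homo sapiens) for cytotoxicity (on this read-out higher numbers stand for lower toxicity in this test and lower numbers for higher toxicity in this test), three compounds built on a shared core have numbers so far. Compound 1 (`Nc1nc(OCC2CC2)c2ncn(/C=C3/C[C@@H]3CO)c2n1`) gives 112000 nM, compound 2 (`CCCCCSc1nc(N)nc2c1ncn2/C=C1/C[C@@H]1CO`) gives 215000 nM and compound 3 (`C=CCOc1nc(N)nc2c1ncn2/C=C1/C[C@@H]1CO`) gives 220000 nM. Compound 3 lies within the scatter of both others, so the three form a single group on these numbers.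

Compound 4 (`C=CCNc1nc(N)nc2c1ncn2/C=C1/C[C@@H]1CO`) has allylamino in place of allyloxy on an aromatic carbon. Among the compounds with values here, no measured step makes this exact swap, and no measured compound carries allylamino. The closest evidence comes from other changes in the group on an aromatic carbon or in the chain it carries: a 1.9-fold higher number from compound 1 to compound 2 (0.28 log units; within the scatter), a 1.0-fold higher number from compound 2 to compound 3 (0.01 log units; within the scatter) and a 2.0-fold higher number from compound 1 to compound 3 (0.29 log units; within the scatter). All three stay within the scatter, so no step beyond the scatter is expected here, and the estimated change is a 1.3-fold lower number from compound 3 to compound 4 (0.11 log units; within the scatter). For compound 4 the expected value is 170000 nM, within an estimated range of 70000 nM to 350000 nM.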

Compound 4, half-maximal cytotoxic concentration: > 368000 nM
Compound 4: only a limit was reported (the forecaster's own chance of this, stated with the estimate: 15%); at least 2.1-fold (0.33 log units) between middle value and limit.
By their numbers in this assay, from the lowest: compounds 1, 2 and 3 (each within the scatter of the next). At a limit, above all of these: compound 4.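

In this assay compound 4 gives only a limit, > 368000 nM, and not an exact number. Read against that limit, allylamino in place of allyloxy gives an at least 1.6-fold higher number from compound 3 to compound 4 (0.22 log units; that floor lies within the scatter), and allylamino in place of pentylsulfanyl gives an at least 1.7-fold higher number from compound 2 to compound 4 (0.23 log units; that floor lies within the scatter); both floors lie within the scatter, so these swaps at the aromatic carbon may have little effect or a larger one. Allylamino in place of cyclopropylmethoxy gives an at least 3.2-fold higher number from compound 1 to compound 4 (0.51 log units; beyond the scatter), which is the first step in this small set to clear the scatter.

On these data alone, how far the true number for compound 4 lies past its limit remains unknown, so the full size of each step stays open. Also open, as far as these compounds go, is whether pentylamino or cyclopropylmethylamino at this position would follow allylamino.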